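Swapping 4-methoxyphenyl for naphthalen-1-yl in compound 3

The source may hold more compounds than are shown below. What is called first, only, known or untested is meant among the compounds shown, and "the series" means these compounds.

Compound 1 `CCOC(=O)C1=C(C[Se]C(=O)c2ccc(C)cc2)NC(=O)NC1c1ccc(O)c(OC)c1` gives 8100 nM
Compound 2 `CCOC(=O)C1=C(C[Se]C(=O)c2ccc(C)cc2)NC(=O)NC1c1ccc(OC)cc1` gives 22500 nM

Among the measured compounds shown here, in a physicochemical assay, read by spectrophotometry, with a stated time of 10 min (on this read-out lower numbers stand for an effect already at smaller amounts and higher numbers for an effect only at larger amounts of compound), compound 2 (22500 nM) carries the higher of the two numbers so far, so it needs the larger amount to show its effect. Compound 3 `CCOC(=O)C1=C(C[Se]C(=O)c2ccc(C)cc2)NC(=O)NC1c1cccc2ccccc12` keeps the shared core and changes one group: naphthalen-1-yl in place of 4-methoxyphenyl on a saturated ring carbon. For the measured compounds named here, only one measured step touches this place, and it is modest (a 2.8-fold higher number from compound 1 to compound 2 (0.44 log units; beyond the scatter)). Going by the values given here, it shows that a change here can move the number, but it involves a different pair of groups, and no measured compound carries naphthalen-1-yl. The data therefore give no direction, so in this assay only a small step, possibly none beyond the usual scatter, is expected (a 1.1-fold higher number from compound 2 to compound 3 (0.05 log units; within the scatter)). For compound 3 the estimated value is 25000 nM (expected range 10000 nM to 60000 nM).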

Compound 3, half-maximal effective concentration: 35500 nM
Compound 3: middle estimate off by 1.4-fold (0.15 log units), on the low side, and the stated range covers the measured number.
By their numbers in this assay, from the lowest: compound 1; then compounds 2 and 3 (each within the scatter of the next).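

In this assay, the position on the saturated ring carbon accepts naphthalen-1-yl, with its 2 six-membered aromatic rings, with no clear separation from 4-methoxyphenyl: the swap gives a 1.6-fold higher number from compound 2 to compound 3 (0.20 log units; within the scatter) and so stays inside the normal spread of repeat measurements. Against 4-hydroxy-3-methoxyphenyl, the same group gives a 4.4-fold higher number from compound 1 to compound 3 (0.64 log units; beyond the scatter) and this step lies beyond that spread, so among these three compounds compound 1 alone stands apart, and it alone carries a hydroxy group. Nothing measured explains these numbers.

The compounds shown do not separate the hydroxy group of compound 1 from its methoxy group, as the two always occur together. On these data alone, whether the hydroxy group alone, as in 4-hydroxyphenyl, or an amine, as in 4-aminophenyl, would give a lower number at this position also stays open.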